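The source may hold more compounds than are shown below. What is called first, only, known or untested is meant among the compounds shown, and "the series" means these compounds.

Measured compounds:
- compound 1, `Oc1cc(C(F)(F)F)ccc1-c1nc(-c2ccccc2O)n(-c2ccc(C(F)(F)F)cc2)n1`: 102%
- compound 2, `Oc1cc(C(F)(F)F)ccc1-c1nc(-c2ccccc2O)n(-c2ccccc2F)n1`: 100%
- compound 3, `Cc1ccc(-n2nc(-c3ccc(C(F)(F)F)cc3O)nc2-c2ccccc2O)c(C)c1`: 106%

All three values come from a functional assay on PC-12 cells (Rattus norvegicus) for cytotoxicity, read by MTT assay, with stated times of 2 h and 24 h, tested at 10 uM; a higher number here means a stronger effect of the compound at the concentration tested, a lower number a weaker effect. Where compound 3 stands: its step from compound 1 is a number 4 percentage points higher from compound 1 to compound 3 (within the scatter) and its step from compound 2 is a number 6 percentage points higher from compound 2 to compound 3 (within the scatter), so the three numbers do not separate from one another on this read-out. Going by the values given here, the only steps measured are changes of the group on the aromatic nitrogen of the shared core, and none of them moved the number: a number 2 percentage points lower from compound 1 to compound 2 (within the scatter) alongside the two already named.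

Compound 4, `Oc1cc(C(F)(F)F)ccc1-c1nc(-c2ccccc2O)n(-c2ccc(Cl)cc2Cl)n1`, is the next member. 2,4-dichlorophenyl in place of 2,4-dimethylphenyl on an aromatic nitrogen

Among the compounds with values here, the steps that bear on this change are those at the same position, from compound 1 to compound 3, from compound 2 to compound 3 and from compound 1 to compound 2, each within the scatter. Three different aryl groups on this nitrogen gave the same result, so for compound 4 no step beyond the scatter is expected in this assay, in either direction: the expected step is a number 3 percentage points lower from compound 3 to compound 4 (within the scatter).

Compound 4 is therefore estimated at 103%, with a range from 93% to 113%.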

Compound 4, a percentage reported as activity, at one concentration (the size of the read-out at that concentration, not a potency): 95.2%
Estimate against measurement, compound 4: 7.8 percentage points above, within the range that was stated.
By their numbers in this assay, from the lowest: compounds 4, 2, 1 and 3 (each within the scatter of the next, the first and the last beyond it).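

In this assay, going by these compounds alone, 2,4-dichlorophenyl in place of 2,4-dimethylphenyl on the aromatic nitrogen gives a number 10.8 percentage points lower from compound 3 to compound 4 (beyond the scatter) and is the first step at this position to pass beyond the scatter. The position is therefore not wholly indifferent to the aryl group it carries, but the separation rests on this one pair, since the same group set against the other two aryl groups gives a number 4.8 percentage points lower from compound 2 to compound 4 (within the scatter) and a number 6.8 percentage points lower from compound 1 to compound 4 (within the scatter) and does not separate from either. No measurement on hand accounts for the modest step between the dichloro and dimethyl compounds.

As far as these compounds go, whether that step belongs to the two chlorine atoms together or to one of them alone stays open, as a 4-chlorophenyl or a 2-chlorophenyl group on this nitrogen would be needed to divide it. All the groups shown here are substituted phenyl rings, so what an aminophenyl group or a longer alkyl chain on the same nitrogen would give in this assay also remains open.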